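Dropping the Methoxy Group: Compound 2 to Compound 3

The compounds below may be only part of what the source reports. "The series", "measured", "known", "first", "only" and "open" are said of these compounds alone.

Compound 1 `O=C(Nc1nc2ccc([N+](=O)[O-])cc2s1)c1ccc(C(F)(F)F)cc1` gives 1.89 ug/mL in a functional assay on MDA-MB-231 cells (Homo sapiens) for antiproliferative activity, read by sulforhodamine B assay; on this read-out higher numbers stand for weaker inhibition of growth and lower numbers for stronger inhibition of growth. Compound 2 `COc1ccccc1NC(=O)Nc1nc2ccc(F)cc2s1` is reported in this assay only as > 10 ug/mL, a limit of the assay rather than a number. This is the limit of > 10 ug/mL in this assay, at which 1 of the 2 values shown sits. Compound 3 `O=C(Nc1ccccc1)Nc1nc2ccc(F)cc2s1` differs from compound 2 by hydrogen in place of methoxy on an aromatic carbon. Among the compounds with values here, with compound 2 known only by a limit, no measured pair sets the size of this step. The step that the limit leaves unreadable from compound 2 to compound 3 is expected to remain within the usual scatter, leaving weak growth inhibition. Compound 3 is therefore expected near 12 ug/mL, between 4 ug/mL and 30 ug/mL.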

Compound 3, concentration for 50% growth inhibition: > 10 ug/mL
Compound 3 ended at the assay's limit (the forecaster's own chance of this, stated with the estimate: 65%); the middle value lies beyond the limit too.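

No step can be read between compound 2 and compound 3, since each is known only as a limit: the limit of > 10 ug/mL in this assay, at which 2 of the 3 values shown sit.

The compounds shown leave open whether hydrogen in place of methoxy on an aromatic carbon changes growth inhibition in this assay at all.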